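A few compounds are considered here, and "the series" means these few. Any claim that something is new, unique, unknown or untested is made for them only; others in the source may bear on it.

Measured in a functional assay on HL-60 cells (Homo sapiens) for cytotoxicity, read by MTT assay, with a stated time of 72 h; on this read-out lower numbers stand for stronger inhibition and higher numbers for weaker inhibition:
- Compound 1 `Cc1ccc(S(=O)(=O)n2cc(COC3=C/C(=N\c4ccccc4)c4ccccc4C3=O)nn2)cc1`: 6710 nM
- Compound 2 `Cc1ccc(S(=O)(=O)n2cc(COC3=C/C(=N\c4ccc(Br)cc4)c4ccccc4C3=O)nn2)cc1`: 4220 nM
- Compound 3 `Cc1ccc(S(=O)(=O)n2cc(COC3=C/C(=N\c4ccc(F)cc4)c4ccccc4C3=O)nn2)cc1`: 7520 nM

All three values lie within the scatter of one another, so compound 3, at 7520 nM, is not set apart from the other two. Compound 4 `Cc1ccc(S(=O)(=O)n2cc(COC3=C/C(=N\c4ccc(Cl)cc4)c4ccccc4C3=O)nn2)cc1` differs from compound 3 as follows: chloro in place of fluoro on an aromatic carbon. This places chloro in place of fluoro on an aromatic carbon. Within the data shown here, three measured steps bear on this change: a 1.1-fold higher number from compound 1 to compound 3 (0.05 log units; within the scatter), a 1.6-fold lower number from compound 1 to compound 2 (0.20 log units; within the scatter) and a 1.8-fold higher number from compound 2 to compound 3 (0.25 log units; within the scatter). Each stays within the scatter, so no step beyond the scatter is expected in this assay. The expected step is a 1.4-fold lower number from compound 3 to compound 4 (0.14 log units; within the scatter). For compound 4 the estimated value is 5500 nM, with an expected range of 3000 nM to 10000 nM.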

Compound 4, half-maximal inhibitory concentration: 6920 nM
Compound 4: the middle estimate sits 1.3-fold (0.10 log units) below what was measured; the range from low to high includes it.
By their numbers in this assay, from the lowest: compounds 2, 1, 4 and 3 (each within the scatter of the next).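

In this assay, chloro on this aromatic carbon, para to a large group, gives a 1.1-fold lower number from compound 3 to compound 4 (0.04 log units; within the scatter), a 1.6-fold higher number from compound 2 to compound 4 (0.21 log units; within the scatter) and a 1.0-fold higher number from compound 1 to compound 4 (0.01 log units; within the scatter). With chloro added, hydrogen, fluoro, chloro and bromo have all been seen at this place, and none of the steps among these four compounds leaves the scatter. Swapping one of these halogens for another, or for hydrogen, therefore shows no measurable effect here.

Going by these compounds, whether an amine, a methoxy group or a carboxylic acid at this place would step beyond the scatter stays open. Nothing available explains why these four compounds sit so close together.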